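This account rests on a few compounds, and the source may have more. Where it says the series, first, only, none or still open, it means among the compounds named here.

In a functional assay on KB cells (Homo sapiens) for inhibition, with a stated time of 72 h (on this read-out higher numbers stand for weaker inhibition and lower numbers for stronger inhibition), compound 1 `CCn1ccc2cc(C(=O)c3cc(OC)c(OC)c(OC)c3)ccc21` gives 36 nM, while compound 2 `CCCn1ccc2cc(C(=O)c3cc(OC)c(OC)c(OC)c3)ccc21` gives 1900 nM. Compound 2 therefore holds the higher of the two numbers, which makes it the weaker inhibitor of the pair. Compound 3 `COc1cc(C(=O)c2ccc3c(ccn3C(C)C)c2)cc(OC)c1OC` has not yet been measured. It differs from compound 2 by one change: isopropyl in place of propyl on an aromatic nitrogen. Isopropyl stands in place of propyl on an aromatic nitrogen, so the atoms stay the same and only the way they are joined differs.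

Going by the values given here, only one measured step bears on this change: a 53-fold higher number from compound 1 to compound 2 (1.72 log units; beyond the scatter). This large step came from a methyl in place of hydrogen on a saturated chain carbon, two bonds along the chain from an aromatic nitrogen. It shows that, in this pair, a small edit to the group on that nitrogen can move the number a long way. Among the compounds with values here, no measured compound carries isopropyl, so the size of the next step remains uncertain. A partial return towards compound 1 seems the more likely outcome, and the expected step is a 4.8-fold lower number from compound 2 to compound 3 (0.68 log units; beyond the scatter) in this assay. For compound 3 the estimated value is 400 nM, with an expected range of 60 nM to 2500 nM.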

Compound 3, half-maximal inhibitory concentration: 1800 nM
For compound 3 the middle estimate is 4.5-fold (0.65 log units) below the measured one, and the stated range covers the measured number.
By their numbers in this assay, from the lowest: compound 1; then compounds 3 and 2 (each within the scatter of the next).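

In this assay, turning the straight propyl into the branched isopropyl leaves the read-out essentially unmoved, with a 1.1-fold lower number from compound 2 to compound 3 (0.02 log units; within the scatter), so at this aromatic nitrogen the way these atoms are joined makes no difference that can be told from the scatter. The earlier pair showed only that going from ethyl to propyl carried a large cost; now a 50-fold higher number from compound 1 to compound 3 (1.70 log units; beyond the scatter) shows that the branched group with 3 carbons stands just as far from compound 1, so among these three compounds the number follows the count of carbons in the group and not their arrangement. The data contain no measurement that explains why ethyl and the two larger groups differ so sharply.

Still open, from the compounds shown here alone, is how a methyl, a cyclopropyl or a longer chain such as butyl on this nitrogen would read, and so whether the low number of compound 1, at 36 nM, belongs to a narrow window or a broader range of groups. Going by these compounds, it also remains open whether the match between propyl and isopropyl would hold for other groups with 3 carbons or in other assays.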